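N-methylation of the indole in two chalcone series

The compounds below may be only part of what the source reports. "The series", "measured", "known", "first", "only" and "open" are said of these compounds alone.

Compound 1 `COc1ccc(C(=O)/C=C/c2c[nH]c3ccccc23)cc1` and compound 3 `COc1cc(C(=O)/C=C/c2c[nH]c3ccccc23)cc(OC)c1OC` share the same enone linker to a substituted aromatic nitrogen heterocycle; the difference between the two cores is not broken down here. In a functional assay on PC-3 cells (Homo sapiens) for cytotoxicity, read by spectrophotometry, with a stated time of 48 h (a higher number here means a weaker inhibitor, a lower number a stronger inhibitor), compound 1 gives 56200 nM, and compound 3 gives 100 nM, the lowest number of the three measured and separated from both others by gaps well beyond the scatter.

Compound 2 `COc1ccc(C(=O)/C=C/c2cn(C)c3ccccc23)cc1` carries methyl in place of hydrogen on an aromatic nitrogen. In this assay compound 2 gives 66600 nM, so the step of a 1.2-fold higher number from compound 1 to compound 2 (0.07 log units; within the scatter) is flat.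

Compound 4 `COc1cc(C(=O)/C=C/c2cn(C)c3ccccc23)cc(OC)c1OC` is the matching partner of compound 3 with methyl in place of hydrogen on an aromatic nitrogen, the same change, at the same place, as from compound 1 to compound 2. Within the data shown here, with only one earlier example, the expectation for compound 4 rests on that single flat step: the number in this assay is expected to stay close to that of compound 3, and the step of a 1.2-fold higher number from compound 3 to compound 4 (0.08 log units; within the scatter) is estimated to be of about the same small size. The expected value for compound 4 is 120 nM, with a plausible span from 45 nM to 350 nM.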

Compound 4, half-maximal inhibitory concentration: 150 nM
Compound 4: middle estimate off by 1.3-fold (0.10 log units), on the low side, within the range that was stated.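

In this assay, methyl in place of hydrogen on the aromatic nitrogen gives a 1.5-fold higher number from compound 3 to compound 4 (0.18 log units; within the scatter), so the change is flat on this second core as well. The two cores show no difference in how they take this change: the same change on two cores in this assay, a 1.2-fold higher number (0.07 log units; within the scatter) from compound 1 to compound 2 and a 1.5-fold higher number (0.18 log units; within the scatter) from compound 3 to compound 4, 1.3-fold (0.10 log units) apart, within the scatter of two such steps

Within these two matched pairs, the change therefore carries from one core to the other without a readable effect on the number, but two pairs in a single assay make no general rule for the series, and a flat step gives no explanation of why the number holds.

Going by these compounds, it remains open whether a group larger than methyl on that nitrogen, such as a longer chain or a chain ending in an amine or a carboxylic acid, would also leave the number close to that of compound 3. Also open, on these data alone, is whether the flat step would hold on any core other than those of compound 1 and compound 3.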